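Iodo in place of isopropyl on the sulfonate-bearing ring

This account rests on a few compounds, and the source may have more. Where it says the series, first, only, none or still open, it means among the compounds named here.

Three aryl sulfonate anilides have been measured in a functional assay on HT-29 cells (Homo sapiens) for antiproliferative activity, read by sulforhodamine B assay, with a stated time of 48 h; on this read-out higher numbers stand for weaker inhibition and lower numbers for stronger inhibition. Compound 1 `CC(=O)Nc1ccc(S(=O)(=O)Oc2ccccc2I)cc1` gives 23000 nM, compound 2 `CCCC(=O)Nc1ccc(S(=O)(=O)Oc2ccccc2I)cc1` gives 11000 nM, and compound 3 `CC(C)c1ccccc1OS(=O)(=O)c1ccc(NC(=O)CCCl)cc1` gives 16000 nM. Among these three numbers compound 3 stands second highest: its value and that of compound 1 lie within the scatter of each other, as do its value and that of compound 2. Within the data shown here, the one step that can be traced between measured compounds runs along the amide chain, a 2.1-fold lower number from compound 1 to compound 2 (0.32 log units; beyond the scatter).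

Compound 4 `O=C(CCCl)Nc1ccc(S(=O)(=O)Oc2ccccc2I)cc1` is not yet measured. It differs from compound 3 in a single place: iodo in place of isopropyl on an aromatic carbon, on an aromatic carbon of a six-membered aromatic ring of carbon only, ortho to a large group. Among the measured compounds shown here, no measured step concerns this exchange; the step from compound 1 to compound 2 touches the amide chain and not the ring bearing the sulfonate oxygen. Compounds 1 and 2 do carry the iodo group, and their values bracket that of compound 3 within the scatter.

On that basis compound 4 is expected to stay close to compound 3, with no step beyond the scatter, a 1.1-fold lower number from compound 3 to compound 4 (0.06 log units; within the scatter). The estimate for compound 4 in this assay is 14000 nM, within a range from 6000 nM to 35000 nM.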

Compound 4, half-maximal inhibitory concentration: 14000 nM
Estimate against measurement, compound 4: no gap at the digits printed; measured number inside the range.
By their numbers in this assay, from the lowest: compounds 2, 4, 3 and 1 (each within the scatter of the next, the first and the last beyond it).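

In this assay, among these compounds, iodo in place of isopropyl on an aromatic carbon, ortho to a large group, gives a step within the scatter (a 1.1-fold lower number from compound 3 to compound 4 (0.06 log units; within the scatter)), so this is the first direct reading of the exchange, and at this position it leaves the number unmoved beyond the scatter even though 3 heavy atoms leave and 1 enters. With the iodo group held fixed, the chloro-bearing amide chain of compound 4 lies within the scatter of both earlier chains, through chloro in place of methyl (a 1.3-fold higher number from compound 2 to compound 4 (0.10 log units; within the scatter)) and through chloromethyl in place of hydrogen (a 1.6-fold lower number from compound 1 to compound 4 (0.22 log units; within the scatter)), although the step between those two earlier chains lies just beyond it. Nothing available explains why these exchanges on the ring and the chain leave the number where it is.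

From the compounds shown here alone, the exchange of isopropyl for iodo is seen on this one chloro-bearing chain only, so it remains open whether it would read the same with the shorter or the longer of the other amide chains. Also open, going by these compounds, is whether a methoxy or a carboxylic acid on that aromatic carbon, or an amine or a longer chain on the amide side, would move the number beyond the scatter.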